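Dropping the fluoro substituent from the shared core

The source may report more compounds than this note shows. Statements on the series, on what has been measured and on what is new or still open speak of the compounds shown alone.

Compound 3 `Cc1cccc(N2CCN(CCCCNc3nc(NCc4ccco4)c4cc(F)ccc4n3)CC2)c1C` gives 820 nM in a functional assay on HCT-116 cells (Homo sapiens) for cytotoxicity, read by MTT assay, with a stated time of 2 days; a lower number here means a stronger inhibitor, a higher number a weaker inhibitor. Among the three compounds measured, compound 3 stands second highest. Its nearest neighbour is compound 1 `Fc1ccc2nc(NCCCCN3CCN(c4cccc(Cl)c4Cl)CC3)nc(NCc3ccco3)c2c1`, which gives 520 nM; the step of a 1.6-fold higher number from compound 1 to compound 3 (0.20 log units; within the scatter) is within the scatter. Compound 2 `Clc1cccc(N2CCN(CCCNc3nc(NCc4ccco4)c4ccccc4n3)CC2)c1Cl` gives 3360 nM, a number beyond the scatter from compound 3.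

Compound 4 `Cc1cccc(N2CCN(CCCCNc3nc(NCc4ccco4)c4ccccc4n3)CC2)c1C` differs from compound 3 in one place: hydrogen in place of fluoro on an aromatic carbon. Among the compounds with values here, no measured pair isolates this change. Compound 1 and compound 2 differ both in the fluoro and in the length of the chain between the two amine nitrogens, so their values alone cannot tell how much the fluoro contributes. Within the data shown here, the only single-point step on record, the exchange of the aryl group on the piperazine, was within the scatter.

Among the measured compounds shown here, with no direct precedent, compound 4 is expected to come out close to compound 3, perhaps somewhat weaker, a step of a 1.5-fold higher number from compound 3 to compound 4 (0.17 log units; within the scatter). The estimate for compound 4 is 1200 nM, with a range from 500 nM to 3000 nM.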

Compound 4, half-maximal inhibitory concentration: 840 nM
The estimate for compound 4 lay 1.4-fold (0.15 log units) above the measured number; the range from low to high includes it.
By their numbers in this assay, from the lowest: compounds 1, 3 and 4 (each within the scatter of the next); then compound 2.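

In this assay, within the data shown here, the step of a 1.0-fold higher number from compound 3 to compound 4 (0.01 log units; within the scatter) comes from hydrogen in place of fluoro on an aromatic carbon, and this is the first measured pair that isolates this change. With the 2,3-dimethylphenyl group and the rest of compound 4 held the same as in compound 3, removing this single fluorine atom causes no change that can be told apart from the usual variation between repeated measurements. Nothing on hand explains why the number stays put.

Among these compounds, whether the fluoro is just as silent when 2,3-dichlorophenyl sits on the ring amine nitrogen remains open, since this pair tests it with only one aryl group. Also open, on these data alone, is whether a different group on this same carbon, such as chloro, methoxy, trifluoromethyl or nitrile, would move the number beyond the scatter.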